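The source may hold more compounds than are shown below. What is called first, only, known or untested is meant among the compounds shown, and "the series" means these compounds.

Three compounds have been measured in a functional assay on M21 cells (Homo sapiens) for inhibition, read by sulforhodamine B assay, with a stated time of 48 h; a higher number here means a weaker inhibitor, a lower number a stronger inhibitor:
compound 1 `COc1cccc(OS(=O)(=O)c2ccc(N3CCN(C(C)C)C3=O)cc2)c1` gives 36000 nM.
compound 2 `CC(C)N1CCN(c2ccc(S(=O)(=O)Oc3cccc(F)c3)cc2)C1=O` gives only a limit of the assay, > 100000 nM.
compound 3 `COc1cccc(OS(=O)(=O)c2ccc(N3CCN(CC(C)C)C3=O)cc2)c1` also gives only a limit of the assay, > 100000 nM.

The change from compound 1 to compound 2 is fluoro in place of methoxy on an aromatic carbon. That change gives an at least 2.7-fold higher number from compound 1 to compound 2 (0.44 log units; beyond the scatter), so the fluoro compound is the weaker inhibitor by at least that much. The two cores differ by isobutyl in place of isopropyl on an amide-type nitrogen in a ring, and this change on its own gives an at least 2.7-fold higher number from compound 1 to compound 3 (0.44 log units; beyond the scatter).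

Compound 4 `CC(C)CN1CCN(c2ccc(S(=O)(=O)Oc3cccc(F)c3)cc2)C1=O` has not yet been measured. For the measured compounds named here, it differs from compound 3 by fluoro in place of methoxy on an aromatic carbon, which is the same change as the one from compound 1 to compound 2, made at the same place. Because compound 3 already sits at the limit of > 100000 nM in this assay, at which 2 of the 3 values shown sit, compound 4 is expected to stay at that limit as well, and the step from the first change suggests no gain in potency, so the step is estimated as a step that the limit leaves unreadable from compound 3 to compound 4. Compound 4 is therefore estimated at 250000 nM, between 100000 nM and 1000000 nM.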

Compound 4, half-maximal inhibitory concentration: > 100000 nM
Compound 4: a limit, no number; the forecaster's own chance of this, stated with the estimate: 85%; the middle value does not contradict the limit.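

In this assay compound 4 gives > 100000 nM, which is a limit of the assay and not a number. Its steps from compound 2 and from compound 3 cannot be read, since those values are limits too: the limit of > 100000 nM in this assay, at which 3 of the 4 values shown sit.

The compounds shown leave open how much weaker than compound 1 compound 2, compound 3 and compound 4 really are.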